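The source may hold more compounds than are shown below. What is called first, only, known or untested is meant among the compounds shown, and "the series" means these compounds.

Compounds measured so far:
Compound 1, `COC(=O)CN1C(=O)c2ccccc2NC1c1ccco1`, 44 nM
Compound 2, `COC(=O)C(C)N1C(=O)c2ccccc2NC1c1ccco1`, 8.2 nM

In an assay on mitochondria for inhibition of Amine oxidase [flavin-containing] A (Bos taurus), read by fluorescence, with a stated time of 60 min (a higher number here means a weaker inhibitor, a lower number a stronger inhibitor), compound 2 holds the lowest of the two numbers recorded. Among the compounds with values here, its only neighbour is compound 1, and the step from compound 1 to compound 2 was a 5.4-fold lower number from compound 1 to compound 2 (0.73 log units; beyond the scatter), a change consisting of a methyl in place of hydrogen on a saturated chain carbon bound to an amide-type nitrogen in a ring and a carbonyl carbon.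

Compound 3, `COC(=O)CCCN1C(=O)c2ccccc2NC1c1ccco1`, has not yet been measured in this assay. It differs from compound 2 by 3-(methoxycarbonyl)propyl in place of 1-(methoxycarbonyl)ethyl on an amide-type nitrogen in a ring. Within the data shown here, this change removes the methyl branch that separated compound 1 from compound 2 and at the same time lengthens the chain, a lengthening for which no measured pair gives a guide. Among the measured compounds shown here, the single step that bears on it is a 5.4-fold lower number from compound 1 to compound 2 (0.73 log units; beyond the scatter), and compound 3 resembles compound 1 in carrying an unbranched chain. A higher number than that of compound 2 is therefore expected, of roughly the size seen in that step, though with wide uncertainty. Compound 3 is estimated at 40 nM, within 12 nM to 130 nM, meaning an expected step of a 4.9-fold higher number from compound 2 to compound 3 (0.69 log units; beyond the scatter).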

Compound 3, half-maximal inhibitory concentration: 96 nM
Beside the measured number, compound 3's estimate is 2.4-fold (0.38 log units) below it, and the stated range covers the measured number.
By their numbers in this assay, from the lowest: compound 2; then compound 1; then compound 3.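

In this assay, within the data shown here, 3-(methoxycarbonyl)propyl in place of 1-(methoxycarbonyl)ethyl on the amide-type nitrogen in a ring gives a 12-fold higher number from compound 2 to compound 3 (1.07 log units; beyond the scatter) and so exceeds in size the one step known before, which had only added a methyl branch. The comparison of the two unbranched chains adds something the earlier pair could not show: 2-(methoxycarbonyl)ethyl in place of methoxycarbonyl on the saturated chain carbon gives a 2.2-fold higher number from compound 1 to compound 3 (0.34 log units; beyond the scatter), so chain length at this position moves the number as well, and by less than the full change from the branched chain to the longer one. Nothing measured here accounts for either step.

The compounds shown leave open whether a methyl branch on the longer chain would lower the number as it did on the shorter one, and whether a still longer chain would raise it further. They also leave open whether the methoxycarbonyl group itself matters, which a carboxylic acid or a primary amide at the end of the chain would test.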